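Removing a Methoxy Group from a Bis-indole Scaffold

The source may report more compounds than this note shows. Statements on the series, on what has been measured and on what is new or still open speak of the compounds shown alone.

The series rests on a shared core carrying a nitrile and a carbonyl between two indole units. Compound 2 `COc1ccc2c(C(=O)/C(C#N)=C/c3c[nH]c4cc(F)ccc34)c[nH]c2c1` gives 36000 nM in a functional assay on PC-3 cells (Homo sapiens) for cytotoxicity, read by WST assay, with a stated time of 24 h; on this read-out lower numbers stand for stronger inhibition and higher numbers for weaker inhibition. Compound 3 `COc1ccc2c(C(=O)/C(C#N)=C/c3c[nH]c4ccc(OC)cc34)c[nH]c2c1` gives 31100 nM in this assay, and the difference between the cores of compound 2 and compound 3 is not broken down here. For compound 1 `N#C/C(=C\c1c[nH]c2cc(F)ccc12)C(=O)c1c[nH]c2ccccc12`, this assay reports only a limit, > 50000 nM. The change hydrogen in place of methoxy on an aromatic carbon thus produced an at least 1.3-fold higher number from compound 2 to compound 1 (0.14 log units; that floor lies within the scatter), and the value of compound 1 sits at the limit of > 50000 nM in this assay, at which 1 of the 3 values shown sits. Compound 4 `COc1ccc2c(C(=O)/C(C#N)=C/c3c[nH]c4ccccc34)c[nH]c2c1` has not yet been measured; it arises from compound 3 by hydrogen in place of methoxy on an aromatic carbon, the same change at the same kind of place. The weak inhibition of compound 2 and compound 3 leads to an expected step of a 1.3-fold higher number from compound 3 to compound 4 (0.11 log units; within the scatter). Compound 4 is therefore estimated at 40000 nM, roughly between 18000 nM and 90000 nM.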

Compound 4, half-maximal inhibitory concentration: > 50000 nM
Compound 4: only a limit was reported; the forecaster's own chance of this, stated with the estimate: 35%; middle value at least 1.2-fold (0.09 log units) away from the limit.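

Putting hydrogen in place of methoxy gave an at least 1.6-fold higher number from compound 3 to compound 4 (0.20 log units; that floor lies within the scatter), while putting hydrogen in place of fluoro gave an at least 1.3-fold higher number from compound 2 to compound 4 (0.14 log units; that floor lies within the scatter). In this assay the methoxy change gives floors of the same direction on both cores, but this does not establish that its size carries over from one core to the other: the same change on two cores in this assay, an at least 1.3-fold higher number (0.14 log units; that floor lies within the scatter) from compound 2 to compound 1 and an at least 1.6-fold higher number (0.20 log units; that floor lies within the scatter) from compound 3 to compound 4; the limit leaves it open whether they differ The values of compound 1 and compound 4 are limits, so neither step has a measured size: the limit of > 50000 nM in this assay, at which 2 of the 4 values shown sit.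

The compounds shown leave open how large these steps really are. They also leave open what an amine or a carboxylic acid would do on the same aromatic carbon.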